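The source may report more compounds than this note shows. Statements on the series, on what has been measured and on what is new or still open speak of the compounds shown alone.

Measured compounds:
compound 1 `O=C(COc1ccc(C(=O)/C=C/c2cccc(Cl)c2)cc1)N[C@H]1CCOC1=O` — in a functional assay on MCF7 cells (Homo sapiens) for antiproliferative activity, read by MTT assay, with a stated time of 72 h (on this read-out higher numbers stand for weaker inhibition and lower numbers for stronger inhibition), compound 1 gives 20900 nM.
compound 2 `O=C1OCC[C@@H]1NC(=S)SCCOc1ccc([N+](=O)[O-])cc1` — in this assay compound 2 reaches only a limit of > 64000 nM, not a number.
compound 3 `O=C1OCC[C@@H]1NC(=S)SCCOc1ccccc1Cc1ccccc1` — in this assay compound 3 gives 39500 nM.

Compound 1 holds the lowest of the two numbers shown, while the reading of compound 3 lies within the usual scatter of it, so no order between these two can be stated. Compound 2 sits at the limit of > 64000 nM in this assay, at which 1 of the 3 values shown sits. Compound 4 `CC(C)c1ccc(/C=C/C(=O)c2ccc(OCC(=O)N[C@H]3CCOC3=O)cc2)cc1` differs from compound 1 in one place: 4-isopropylphenyl in place of 3-chlorophenyl on a double-bonded chain carbon bound to a double-bonded chain carbon. Going by the values given here, no measured pair carries this change, so its direction is open. Compound 4 is expected to remain close to compound 1, with a step of a 1.2-fold higher number from compound 1 to compound 4 (0.08 log units; within the scatter) that stays small. The estimate for compound 4 in this assay is 25000 nM, with a range from 8000 nM to 80000 nM.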

Compound 4, half-maximal inhibitory concentration: 23400 nM
The estimate for compound 4 lay 1.1-fold (0.03 log units) above the measured number; the measured number falls inside the stated range.
By their numbers in this assay, from the lowest: compounds 1, 4 and 3 (each within the scatter of the next). At a limit, above all of these: compound 2.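

At this place, on a double-bonded chain carbon bound to a double-bonded chain carbon, 4-isopropylphenyl in place of 3-chlorophenyl gives, in this assay, a 1.1-fold higher number from compound 1 to compound 4 (0.05 log units; within the scatter). This first measured pair at the position shows that a group of 9 heavy atoms without chlorine and a group of 7 heavy atoms with chlorine cannot be told apart in this read-out. Nothing in the data shown bears on why the two readings coincide.

As far as these compounds go, whether an amine or a carboxylic acid at this place would give a step beyond the scatter remains open. So does whether any group here could bring the number clearly below that of compound 1.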